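This account rests on a few compounds, and the source may have more. Where it says the series, first, only, none or still open, it means among the compounds named here.

Measured compounds:
compound 1 `Cc1cc(C)cc(Oc2nc(NCCn3ccc(=O)[nH]c3=O)ncc2Cl)c1` – > 322000 nM
compound 2 `Cc1cc(C#N)cc(C)c1Oc1cc(Cl)nc(NCCn2ccc(=O)[nH]c2=O)n1` – 20600 nM
compound 3 `Cc1cc(C)cc(Oc2cc(Cl)nc(NCCn3ccc(=O)[nH]c3=O)n2)c1` – > 56400 nM

In an ADME assay on MT4 cells (Homo sapiens) for cytotoxicity, read by MTT assay, with a stated time of 5 days (a lower number here means that less compound is tolerated, a higher number that more compound is tolerated), compound 1 gives only a limit of the assay, > 322000 nM, not a number. Compound 3 likewise stops at a limit, > 56400 nM. Compound 2 gives a number, 20600 nM. Compound 1 thus stands at the limit of > 322000 nM in this assay, at which 1 of the 3 values shown sits, with a second limit present at the limit of > 56400 nM in this assay, at which 1 of the 3 values shown sits. Compound 4 `Cc1cc(C)c(Oc2nc(NCCn3ccc(=O)[nH]c3=O)ncc2Cl)c(C)c1` has not yet been measured; it differs from compound 1 by 2,4,6-trimethylphenyl in place of 3,5-dimethylphenyl on an oxygen on an aromatic ring. Among the measured compounds shown here, no measured pair carries this change, so no measured step guides it. No step beyond the usual scatter is expected: an at least 1.2-fold lower number from compound 1 to compound 4 (0.10 log units; that floor lies within the scatter). Compound 4 is expected to give about 250000 nM, within a range from 80000 nM to 500000 nM, with a fair chance that this assay again reports only a limit.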

Compound 4, half-maximal cytotoxic concentration: 2490 nM
Compound 4: middle estimate off by 100-fold (2.00 log units), on the high side; measured number below the stated range.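

In this assay, the group on this oxygen proves decisive: 2,4,6-trimethylphenyl in place of 3,5-dimethylphenyl gives an at least 120-fold lower number from compound 1 to compound 4 (2.11 log units; beyond the scatter). Among the compounds shown here, a change of only one carbon in the group thus separates a well-tolerated compound from a far less tolerated one, which no earlier compound could show. Compound 1 gives only a limit of the assay, not a number: the limit of > 322000 nM in this assay, at which 1 of the 4 values shown sits.

The compounds shown leave open why this change has so large an effect. They also leave open whether a ring carrying methoxy groups or an amine at this place would behave the same way.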